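This account rests on a few compounds, and the source may have more. Where it says the series, first, only, none or still open, it means among the compounds named here.

In a physicochemical assay for solubility, at pH 7.4 (a lower number here means a less soluble compound, a higher number a more soluble compound), compound 2 `O=C(N[C@H]1CN(S(=O)(=O)c2ccccc2)C[C@@H]1C(=O)N[C@H]1CCCNC1)c1cn(C2CC2)cn1` gives 664000 nM and compound 1 `O=C(N[C@H]1CN(S(=O)(=O)c2ccccc2)C[C@@H]1C(=O)N[C@H]1CCCNC1)c1cc(C2CC2)n[nH]1` gives 861000 nM, two values within the scatter of each other. Compound 3 `Cc1nc(-c2cccc(C(F)(F)F)c2)sc1C(=O)N[C@H]1CN(S(=O)(=O)c2ccccc2)C[C@@H]1C(=O)N[C@H]1CCCNC1`, at 112000 nM, lies clearly lower than both. Compound 4 `O=C(N[C@H]1CN(S(=O)(=O)c2ccccc2)C[C@@H]1C(=O)N[C@H]1CCCNC1)c1nnc(-c2ccc(F)cc2)s1` differs from compound 2 by a group of 12 heavy atoms (8 carbon, 2 nitrogen, 1 fluorine, 1 sulfur; one five-membered aromatic ring with 3 hetero atoms, one six-membered aromatic ring of carbon only) in place of a group of 8 heavy atoms (6 carbon, 2 nitrogen; one three-membered non-aromatic ring of carbon only, one five-membered aromatic ring with 2 hetero atoms), on a carbonyl carbon. Among the measured compounds shown here, the only measured step, a 1.3-fold lower number from compound 1 to compound 2 (0.11 log units; within the scatter), swaps one cyclopropyl-bearing group for another, so it says little about a change of this size. The closer guide is compound 3 at 112000 nM, which also carries two aromatic rings in the group on that carbonyl carbon. A lower number, beyond the scatter, is therefore expected. The estimated step is a 4.7-fold lower number from compound 2 to compound 4 (0.68 log units; beyond the scatter). For compound 4 the estimate is 140000 nM, with an expected range of 50000 nM to 350000 nM.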

Compound 4, solubility: 234000 nM
Beside the measured number, compound 4's estimate is 1.7-fold (0.22 log units) below it, and the stated range covers the measured number.
By their numbers in this assay, from the lowest: compound 3; then compound 4; then compounds 2 and 1 (each within the scatter of the next).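

In this assay the position on the carbonyl carbon now gives steps beyond the scatter, though modest ones: a 2.8-fold lower number from compound 2 to compound 4 (0.45 log units; beyond the scatter) and a 3.7-fold lower number from compound 1 to compound 4 (0.57 log units; beyond the scatter) when the group with a five-membered aromatic ring and a six-membered carbon ring enters. The earlier step at this position, between two cyclopropyl-bearing groups, stayed within the scatter. No supporting data bear on the origin of these steps.

The compounds shown do not separate the contributions of the two rings in the entering group. Going by these compounds, how an amine or a carboxylic acid on the group at this carbonyl carbon would read remains open.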